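One Carbon More on a Methoxy Group

A few compounds are considered here, and "the series" means these few. Any claim that something is new, unique, unknown or untested is made for them only; others in the source may bear on it.

Compound 1 (`CC(C)(CO)CNC(=O)c1cc2cc(C#N)ccc2n1Cc1cccc(OC(F)(F)F)c1`) and compound 2 (`COc1ccc(OC(F)(F)F)cc1Cn1c(C(=O)NCC(C)(C)CO)cc2cc(C#N)ccc21`) have been measured in an in vitro ADME assay on microsomes from Gut (Homo sapiens) for metabolic stability, using NADPH; on this read-out lower numbers stand for slow clearance and higher numbers for fast clearance. In this assay compound 1 gives < 6 mL.min-1.g-1, which is a limit of the assay and not a number. In the same test compound 2 gives < 6 mL.min-1.g-1, which is likewise only a limit.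

Compound 3 (`CCOc1ccc(OC(F)(F)F)cc1Cn1c(C(=O)NCC(C)(C)CO)cc2cc(C#N)ccc21`) differs from compound 2 in one place: methyl in place of hydrogen on a saturated chain carbon bound to an oxygen on an aromatic ring. This is methyl in place of hydrogen on a saturated chain carbon bound to an oxygen on an aromatic ring, so methoxy becomes ethoxy.

Within the data shown here, the one measured step that bears on this change is a step that the two limits leave unreadable from compound 1 to compound 2, which put methoxy in place of hydrogen on an aromatic carbon. Among the measured compounds shown here, the only evidence from it is the limit of < 6 mL.min-1.g-1 in this assay, at which 2 of the 2 values shown sit, so it offers no size to carry over. Lengthening that methoxy to ethoxy is therefore expected to bring no step beyond the usual scatter, and no direction can be favoured. The expected size is a step that the limit leaves unreadable from compound 2 to compound 3. For compound 3 the estimated intrinsic clearance is 5 mL.min-1.g-1, with an expected range from 3 mL.min-1.g-1 to 10 mL.min-1.g-1.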

Compound 3, intrinsic clearance in microsomes: < 6 mL.min-1.g-1
Compound 3 ended at the assay's limit; the forecaster's own chance of this, stated with the estimate: 75%; the middle value is on the limit's open side.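

No step among compound 1, compound 2 and compound 3 can be read in this assay, because all three end at a limit of the assay and not at a number: the limit of < 6 mL.min-1.g-1 in this assay, at which 3 of the 3 values shown sit.

The compounds shown leave open how their true clearances compare, and whether hydrogen, methoxy or ethoxy makes any difference to this read-out.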